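Oleyl chain series: acetal to formyl end group

The compounds below may be only part of what the source reports. "The series", "measured", "known", "first", "only" and "open" are said of these compounds alone.

Three measured compounds frame the question. For the measured compounds named here, compound 1 `O=C(CCCC[S+]([O-])Cc1ccccc1)c1ncc(-c2ccccn2)o1` gives 2500 nM in an assay on isolated protein for inhibition of Fatty-acid amide hydrolase 1 (Homo sapiens) (on this read-out lower numbers stand for stronger inhibition and higher numbers for weaker inhibition), the only numerical value of the set. For compound 3 `CCCCCCCC/C=C\CCCCCCC(=O)c1nc2c(C)cccc2o1` this assay reports only a limit, > 100000 nM, which is the limit of > 100000 nM in this assay, at which 1 of the 3 values shown sits. Compound 2 `CCCCCCCC/C=C\CCCCCCCC(OC)OC` likewise stands only at a limit in this assay, > 300000 nM, which is the limit of > 300000 nM in this assay, at which 1 of the 3 values shown sits; its position on the numbers shown is therefore no more than an upper bound on inhibition, with no measured step to any neighbour.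

Compound 4 `CCCCCCCC/C=C\CCCCCCCC=O` is the next compound, differing from compound 2 as follows: formyl in place of dimethoxymethyl on a saturated chain carbon, seven bonds along the chain from a double-bonded chain carbon. Going by the values given here, since compound 2 is only a limit and no step between measured compounds exists, any step in this assay from compound 2 to compound 4 can only be stated as an expectation. The expected step is an at least 30-fold lower number from compound 2 to compound 4 (1.47 log units; beyond the scatter), towards stronger inhibition. Compound 4 is expected near 10000 nM, within 2000 nM to 100000 nM, with a real chance that this assay again reports only a limit.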

Compound 4, inhibition constant: 190 nM
Beside the measured number, compound 4's estimate is 53-fold (1.72 log units) above it; measured number outside the range, below it.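

In this assay, replacing dimethoxymethyl with formyl on a saturated chain carbon, seven bonds along the chain from a double-bonded chain carbon, gives an at least 1500-fold lower number from compound 2 to compound 4 (3.19 log units; beyond the scatter). With the rest of the structure unchanged, the end group at this position alone separates a limit from a measured value, and it does so by a large margin. Compound 2 is only a limit, so the step is a minimum and its true size remains unknown: the limit of > 300000 nM in this assay, at which 1 of the 4 values shown sits.

From the compounds shown here alone, whether the formyl group itself is required, or removing dimethoxymethyl is enough, remains open; a carboxylic acid, a primary alcohol or a methyl ketone at this chain end would help separate the two. Going by these compounds, how far the result depends on chain length also remains open, and a shorter or longer chain ending in formyl would test it.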